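Thiazole amide in place of the furan amide

A few compounds are considered here, and "the series" means these few. Any claim that something is new, unique, unknown or untested is made for them only; others in the source may bear on it.

In a functional assay on DU-145 cells (Homo sapiens) for inhibition, read by colorimetric assay and sulforhodamine B assay, with a stated time of 48 h (on this read-out lower numbers stand for stronger inhibition of growth and higher numbers for weaker inhibition of growth), compound 3 `CCCCCCCCCCCC[C@@H](O)[C@H]1CC[C@H]([C@H](O)CCCCCCCCCCNC(=O)c2ccoc2)O1` gives 100000 nM and stands level with compound 2 `CCCCCCCCCCCC[C@@H](O)[C@H]1CC[C@H]([C@H](O)CCCCCCCCCCNC(=O)c2ccco2)O1` at 100000 nM as the highest of the three numbers. Going by the values given here, compound 1 `CCCCCCCCCCCC[C@@H](O)[C@H]1CC[C@H]([C@H](O)CCCCCCCCCCNC(=O)c2cccs2)O1` gives 2690 nM as the only lower number. Compound 4 `CCCCCCCCCCCC[C@@H](O)[C@H]1CC[C@H]([C@H](O)CCCCCCCCCCNC(=O)c2cncs2)O1` follows from 1,3-thiazol-5-yl in place of furan-3-yl on a carbonyl carbon on a carbonyl carbon. Among the compounds with values here, the thiophen-2-yl group of compound 1 is the nearest precedent: a 37-fold higher number from compound 1 to compound 2 (1.57 log units; beyond the scatter) and a 37-fold higher number from compound 1 to compound 3 (1.57 log units; beyond the scatter) are both large, while no change at the digits printed from compound 2 to compound 3 (within the scatter) leaves the two furans unseparated. Within the data shown here, the 1,3-thiazol-5-yl group shares sulfur with thiophen-2-yl, but no measured compound carries its nitrogen, so the range stays wide. A large move toward stronger inhibition of growth is expected, estimated as a 17-fold lower number from compound 3 to compound 4 (1.22 log units; beyond the scatter) and beyond the scatter. Compound 4 is estimated at 6000 nM with a range from 1800 nM to 100000 nM as the upper end.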

Compound 4, concentration for 50% growth inhibition: 100000 nM
The estimate for compound 4 lay 17-fold (1.22 log units) below the measured number; the range from low to high includes it.
By their numbers in this assay, from the lowest: compound 1; then compounds 2, 3 and 4 (each within the scatter of the next).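

In this assay, sulfur in the ring on this carbonyl carbon is not enough to keep the lower number of compound 1, with a 37-fold higher number from compound 1 to compound 4 (1.57 log units; beyond the scatter). The 1,3-thiazol-5-yl group sits with both furans, with no change at the digits printed from compound 3 to compound 4 (within the scatter) and no change at the digits printed from compound 2 to compound 4 (within the scatter). No supporting data bear on why the ring nitrogen accompanies this result.

From the compounds shown here alone, whether the lower number belongs to thiophen-2-yl alone remains open. Thiophen-3-yl, phenyl or 1,3-thiazol-2-yl on the same carbonyl carbon would address that.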